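Tert-butyl for fluorophenyl on two weakly cytotoxic cores

A few compounds are considered here, and "the series" means these few. Any claim that something is new, unique, unknown or untested is made for them only; others in the source may bear on it.

Compound 1 `O=C(O)c1cn(-c2ccc(F)cc2)c2nc(N3CCN(C(c4ccccc4)c4ccc(Cl)cc4)CC3)c([N+](=O)[O-])cc2c1=O` gives 102000 nM in an ADME assay on Vero cells (Chlorocebus sabaeus) for cytotoxicity, read by MTT assay, with a stated time of 72 h; on this read-out higher numbers stand for weaker inhibition and lower numbers for stronger inhibition.
Compound 2 `O=C(O)c1cn2c(n1)CN(c1nc3c(cc1[N+](=O)[O-])c(=O)c(C(=O)O)cn3-c1ccc(F)cc1)CC2` reaches only a limit in this assay, > 126000 nM.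
Compound 3 `CC(C)(C)n1cc(C(=O)O)c(=O)c2cc([N+](=O)[O-])c(N3CCN(C(c4ccccc4)c4ccc(Cl)cc4)CC3)nc21` likewise reaches only a limit in this assay, > 108000 nM.

On the core of compound 1 the change tert-butyl in place of 4-fluorophenyl on an aromatic nitrogen made an at least 1.0-fold higher number from compound 1 to compound 3 (0.02 log units; that floor lies within the scatter); that floor comes from the limit of > 108000 nM in this assay, at which 1 of the 3 values shown sits. Compound 4 `CC(C)(C)n1cc(C(=O)O)c(=O)c2cc([N+](=O)[O-])c(N3CCn4cc(C(=O)O)nc4C3)nc21` carries the same change on the core of compound 2, (tert-butyl in place of 4-fluorophenyl on an aromatic nitrogen), with the place described in identical words. The difference between the two cores is not broken down here. Compound 2 stands at the limit of > 126000 nM in this assay, at which 1 of the 3 values shown sits. Since the change moved compound 3 no further than its own limit, compound 4 is expected to remain at or beyond the limit as well, estimated at 130000 nM, between 100000 nM and 200000 nM. That estimate means an expected step that the limit leaves unreadable from compound 2 to compound 4 in this assay.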

Compound 4, half-maximal inhibitory concentration: > 136000 nM
Compound 4 ended at the assay's limit; the forecaster's own chance of this, stated with the estimate: 80%; middle value at least 1.0-fold (0.01 log units) away from the limit.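

Compound 2 and compound 4 both reach only limits, and the step between them cannot be read. The compounds shown leave open how large the effect of tert-butyl in place of 4-fluorophenyl is on either core.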